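The compounds below may be only part of what the source reports. "The series", "measured", "known", "first", "only" and "open" are said of these compounds alone.

Going by the values given here, compound 2 `CCn1c(C(=O)NCCC(=O)O)ccc1C(CC)(CC)c1ccc(C#CC(O)(CC)CC)c(C)c1` is the only compound of the pair with a number in an assay on cells for agonist activity at vitamin D3 receptor (Homo sapiens), read by microscopy; a lower number here means that less compound is needed, a higher number that more compound is needed for the effect: in this assay compound 2 gives 293 nM. Compound 1 `CCn1c(C(=O)NCc2ccc(OC)cc2)ccc1C(CC)(CC)c1ccc(C#CC(O)(CC)CC)c(C)c1` is reported only as a limit in this assay, where compound 1 gives > 50 nM. Among the compounds with values here, the one measured step, a step that the limit leaves unreadable from compound 1 to compound 2, is unreadable because of the limit of > 50 nM in this assay, at which 1 of the 2 values shown sits, and it alters a different part of the molecule in any case. Compound 3 `CCn1c(C(=O)NCCCO)ccc1C(CC)(CC)c1ccc(C#CC(O)(CC)CC)c(C)c1` differs from compound 2 by hydroxymethyl in place of carboxy on a saturated chain carbon, two bonds along the chain from an amide-type nitrogen. Within the data shown here, no measured step bears on this change, so the expected step in this assay is a 1.2-fold lower number from compound 2 to compound 3 (0.07 log units; within the scatter), not beyond the scatter in either direction, with a wide range. Compound 3 is therefore estimated at 250 nM, between 60 nM and 1200 nM.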

Compound 3, half-maximal effective concentration: 137 nM
Estimate against measurement, compound 3: 1.8-fold (0.26 log units) above; the measured number falls inside the stated range.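

In this assay, hydroxymethyl in place of carboxy on a saturated chain carbon, two bonds along the chain from an amide-type nitrogen, gives a 2.1-fold lower number from compound 2 to compound 3 (0.33 log units; beyond the scatter). Going by these compounds alone, this is the first step at this place that can be read, and it shows that the end of this chain affects the number, modestly, and that a carboxy group there is not required for a value in this range. Compound 1 is reported only as a limit, and the steps from it to the other two compounds cannot be read: the limit of > 50 nM in this assay, at which 1 of the 3 values shown sits.

As far as these compounds go, whether an amine, a methyl ether or a longer chain at the same place would lower the number further remains open. From the compounds shown here alone, the size of the step also rests on this single pair, so it is unknown whether the change would do the same with a different amide substituent or on another core.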